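Adding Chloro to the Trifluoromethyl Ring of Compound 3

The source may hold more compounds than are shown below. What is called first, only, known or untested is meant among the compounds shown, and "the series" means these compounds.

The three measured diaryl ureas share one core and differ only in the terminal phenyl ring. In a functional assay on COLO 205 cells (Homo sapiens) for inhibition, read by sulforhodamine B assay, with a stated time of 48 h, tested at 10 uM (on this read-out lower numbers stand for a stronger effect and higher numbers for a weaker effect at the one concentration tested), compound 1 `COc1cc2cc(Oc3ccc(NC(=O)Nc4ccccc4)cc3)c(C)nc2cc1OC` gives 85.7%, compound 2 `COc1cc2cc(Oc3ccc(NC(=O)Nc4ccc(C)cc4)cc3)c(C)nc2cc1OC` gives 111%, and compound 3 `COc1cc2cc(Oc3ccc(NC(=O)Nc4cccc(C(F)(F)F)c4)cc3)c(C)nc2cc1OC` gives -20.2%. Compound 3 stands lowest of the three numbers; its nearest neighbour is compound 1, with a number 105.9 percentage points lower from compound 1 to compound 3 (beyond the scatter), and the furthest is compound 2, with a number 131.2 percentage points lower from compound 2 to compound 3 (beyond the scatter).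

Compound 4 `COc1cc2cc(Oc3ccc(NC(=O)Nc4ccc(Cl)c(C(F)(F)F)c4)cc3)c(C)nc2cc1OC` arises from compound 3 by chloro in place of hydrogen on an aromatic carbon. For the measured compounds named here, no measured step swaps chloro for hydrogen on this ring, so the expectation rests on what substitution of that ring has done so far: a methyl gave a number 25.3 percentage points higher from compound 1 to compound 2 (beyond the scatter), a modest rise, whereas the trifluoromethyl gave a number 105.9 percentage points lower from compound 1 to compound 3 (beyond the scatter), a large drop that compound 4 keeps. With the trifluoromethyl retained, compound 4 is expected to stay in the low region of compound 3, with a number 4.8 percentage points lower from compound 3 to compound 4 (within the scatter) not clearly beyond the scatter in either direction. Compound 4 is therefore estimated at -25% in this assay, within a range of -60% to 30%.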

Compound 4, a percentage reported as activity, at one concentration (the size of the read-out at that concentration, not a potency): -49.6%
The estimate for compound 4 lay 24.6 percentage points above the measured number; low and high end bracket the measured number.
By their numbers in this assay, from the lowest: compound 4; then compound 3; then compound 1; then compound 2.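

The carbon para to a large group and ortho to a trifluoromethyl group is not a spent position: with the trifluoromethyl in place, chloro on that carbon gives a number 29.4 percentage points lower from compound 3 to compound 4 (beyond the scatter) in this assay, a modest step but one that carries the number further down than the trifluoromethyl alone had taken it. The full 4-chloro-3-(trifluoromethyl)phenyl group gives a number 135.3 percentage points lower from compound 1 to compound 4 (beyond the scatter) against the unsubstituted phenyl and a number 160.6 percentage points lower from compound 2 to compound 4 (beyond the scatter) against the 4-methylphenyl, so the lowest number in the set comes from substitution at both places on the terminal ring, although the methyl at the para place in compound 2 went the other way on a ring without trifluoromethyl. No measurement shown here explains why chloro has this effect at this carbon.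

The compounds shown leave open whether chloro would lower the number on a ring without the trifluoromethyl, and what a fluoro, a methoxy, an amine or a carboxylic acid would do on the same carbon. With every compound read at a single concentration, they also leave open whether these stronger and weaker effects would hold at any other concentration.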